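Swapping the benzyl ether for a methylpyridinyl ether

A few compounds are considered here, and "the series" means these few. Any claim that something is new, unique, unknown or untested is made for them only; others in the source may bear on it.

Compound 1 `O=C1NC(=O)C(Cc2ccc(Oc3ccc(Cl)cc3)cc2)S1`: 240 nM
Compound 2 `Cc1cccnc1Oc1ccc(CC2SC(=O)NC2=O)cc1`: 1090 nM
Compound 3 `O=C1NC(=O)C(Cc2ccc(OCc3ccccc3)cc2)S1`: 6180 nM

In a functional assay for agonist activity at Free fatty acid receptor 1 (Homo sapiens), read by FLIPR, in the presence of a further agent that is not named here (on this read-out higher numbers stand for an effect only at larger amounts of compound and lower numbers for an effect already at smaller amounts), compound 3 gives the highest number of the three, so it needs the largest amount of compound for an effect. Its nearest neighbour is compound 2, a 5.7-fold higher number from compound 2 to compound 3 (0.75 log units; beyond the scatter); compound 1 lies furthest away, a 26-fold higher number from compound 1 to compound 3 (1.41 log units; beyond the scatter).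

Compound 4 `Cc1ccc(Oc2ccc(CC3SC(=O)NC3=O)cc2)nc1` differs from compound 3 in one place: 5-methylpyridin-2-yl in place of benzyl on an oxygen on an aromatic ring. Going by the values given here, the step that bears most directly on this change is the one from compound 2 to compound 3, where benzyl took the place of 3-methylpyridin-2-yl and the number rose modestly, a 5.7-fold higher number from compound 2 to compound 3 (0.75 log units; beyond the scatter). Compound 4 carries a methylpyridinyl group at the same oxygen as compound 2, only with the methyl at another position, so reversing that step is expected to lower the number by a similar modest amount, a 6.2-fold lower number from compound 3 to compound 4 (0.79 log units; beyond the scatter). Compound 4 is therefore estimated at 1000 nM in this assay, within 300 nM to 3500 nM.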

Compound 4, half-maximal effective concentration: 4470 nM
Compound 4: the middle estimate sits 4.5-fold (0.65 log units) below what was measured, and the stated range ends below it.
By their numbers in this assay, from the lowest: compound 1; then compound 2; then compounds 4 and 3 (each within the scatter of the next).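

In this assay a methylpyridinyl group on this oxygen does not by itself lower the number: replacing benzyl with 5-methylpyridin-2-yl gives a 1.4-fold lower number from compound 3 to compound 4 (0.14 log units; within the scatter), so these two compounds cannot be told apart. The earlier compounds shown here could not show that the location of the methyl group matters here, and 5-methylpyridin-2-yl in place of 3-methylpyridin-2-yl gives a 4.1-fold higher number from compound 2 to compound 4 (0.61 log units; beyond the scatter). Neither methylpyridinyl group matches the 4-chlorophenyl group at this oxygen, and the change to 5-methylpyridin-2-yl gives a 19-fold higher number from compound 1 to compound 4 (1.27 log units; beyond the scatter).

No measurement offered here explains why the location of the methyl group changes the result. From the compounds shown here alone, it also remains open how a pyridin-2-yl group with no methyl, or one carrying a chlorine or an amine in place of the methyl, would compare at this oxygen.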